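This account rests on a few compounds, and the source may have more. Where it says the series, first, only, none or still open, it means among the compounds named here.

Compound 1, `C#CCN(CCCCOc1ccc2ccc(=O)oc2c1)Cc1ccc(C)cc1`: 1680 nM
Compound 2, `C#CCN(CCCOc1ccc2ccc(=O)oc2c1)Cc1ccc(C(C)C)cc1`: 7580 nM

Of the compounds shown here, two have been measured in an assay on isolated protein for inhibition of Amine oxidase [flavin-containing] B (Homo sapiens), read by fluorescence and Amplex Red, with stated times of 15 min and 20 min; on this read-out higher numbers stand for weaker inhibition and lower numbers for stronger inhibition. Compound 1 gives 1680 nM, the lower of the two numbers and therefore the stronger inhibitor of the pair; compound 2 gives 7580 nM, a higher number whose gap from compound 1 lies beyond the usual scatter. Compound 2 differs from compound 1 in more than one place, so that gap cannot be pinned on a single change. The step followed here leads from compound 1 to compound 3, `C#CCN(C)CCCCOc1ccc2ccc(=O)oc2c1`, which has not yet been measured. The change is hydrogen in place of 4-methylphenyl on a saturated chain carbon bound to an amine nitrogen: the 4-methylbenzyl group on the amine nitrogen shrinks to a methyl group, while the propargyl group, the chain and the shared core remain. Because compound 1 stands at 1680 nM with the larger group present, compound 3 is expected to give a higher number in this assay, a step of a 3.6-fold higher number from compound 1 to compound 3 (0.55 log units; beyond the scatter) beyond the scatter. The estimate for compound 3 is 6000 nM, with a range from 1200 nM to 30000 nM.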

Compound 3, half-maximal inhibitory concentration: 27 nM
Compound 3: the middle estimate sits 220-fold (2.35 log units) above what was measured; measured number below the stated range.
By their numbers in this assay, from the lowest: compound 3; then compound 1; then compound 2.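

In this assay, the group on the amine nitrogen turns out to matter greatly: replacing 4-methylbenzyl with methyl gives a 62-fold lower number from compound 1 to compound 3 (1.79 log units; beyond the scatter). So the 4-methylphenyl part, with its aromatic ring, is not needed for inhibition here, and the compound is far stronger without it, something the first two compounds could not show because they differ in more than one place. Nothing available explains why this single change has so large an effect.

From the compounds shown here alone, only these two groups on the nitrogen can be compared, so it remains open whether an ethyl group or a plain benzyl group would fall closer to compound 3 or to compound 1. It is also unknown whether methyl would bring the same gain on a longer chain.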